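A few compounds are considered here, and "the series" means these few. Any claim that something is new, unique, unknown or untested is made for them only; others in the source may bear on it.

Compound 1 `CN(Cc1cccs1)C1CCN(CCCc2c[nH]c3ccc(-n4cnnc4)cc23)CC1` — in an assay on CHO cells for displacement of a labelled ligand from 5-hydroxytryptamine receptor 1B (Homo sapiens) (a lower number here means a stronger inhibitor, a higher number a weaker inhibitor), compound 1 gives 140 nM.
Compound 2 `c1ccc2c(c1)CCC2NC1CCN(CCCc2c[nH]c3ccc(-n4cnnc4)cc23)CC1` — in this assay compound 2 gives 280 nM.

Compound 2 has the higher of the two numbers, though the step of a 2.0-fold higher number from compound 1 to compound 2 (0.30 log units; within the scatter) lies within the scatter, so neither compound can be called the stronger binder. Compound 3 `c1cc(CNC2CCN(CCCc3c[nH]c4ccc(-n5cnnc5)cc34)CC2)co1` keeps the shared core of compound 2 and changes only the group on the amine nitrogen: (furan-3-yl)methyl in place of 2,3-dihydro-1H-inden-1-yl on an amine nitrogen. Within the data shown here, the single measured step, from compound 1 to compound 2, swapped one amine substituent for another and stayed within the scatter, so a small change at most is expected here; compound 3 is estimated at 200 nM, within 70 nM to 700 nM, a step of a 1.4-fold lower number from compound 2 to compound 3 (0.15 log units; within the scatter).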

Compound 3, half-maximal inhibitory concentration: 78 nM
The estimate for compound 3 lay 2.6-fold (0.41 log units) above the measured number; the range from low to high includes it.
By their numbers in this assay, from the lowest: compounds 3, 1 and 2 (each within the scatter of the next, the first and the last beyond it).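

Swapping 2,3-dihydro-1H-inden-1-yl for (furan-3-yl)methyl on this amine nitrogen gives a 3.6-fold lower number from compound 2 to compound 3 (0.56 log units; beyond the scatter) in this assay, the first step here beyond the scatter, so this substituent can measurably change the number. By contrast, a 1.8-fold lower number from compound 1 to compound 3 (0.25 log units; within the scatter) leaves compound 1 and compound 3 unranked, although their amine substituents differ. No supporting data explain the difference between compound 2 and compound 3. Still open, from the compounds shown here alone, is whether a benzyl or (furan-2-yl)methyl group on the same nitrogen would give a similar number, and whether adding a methyl to the nitrogen of compound 3 would change it.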